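The source may hold more compounds than are shown below. What is called first, only, known or untested is meant among the compounds shown, and "the series" means these compounds.

Values in a functional assay on HT-29 cells (Homo sapiens) for inhibition, read by MTT assay; a lower number here means a stronger inhibitor, a higher number a weaker inhibitor:
Compound 1 `COc1ccc2c(c1)CC[C@H](O)/C2=C/c1cc(OC)c(OC)c(OC)c1`: 1 nM
Compound 2 `COc1ccc2c(c1)CC[C@@H](O)/C2=C/c1cc(OC)c(OC)c(OC)c1`: 900 nM
Compound 3 `COc1ccc(/C=C2\c3cc(OC)c(OC)c(OC)c3CC[C@@H]2O)cc1F`: 3 nM

Compound 3, at 3 nM, has the second highest of the three numbers, lying above compound 1 and well below compound 2. Compound 4 `COc1ccc(/C=C2\c3cc(OC)c(OC)c(OC)c3CC[C@@H]2O)cc1C#N` carries cyano in place of fluoro on an aromatic carbon, ortho to a methoxy group: cyano in place of fluoro on an aromatic carbon. Among the compounds with values here, the only measured step is large, a 900-fold higher number from compound 1 to compound 2 (2.95 log units; beyond the scatter), but it reflects (the fact that compounds 1 and 2 differ only in the configuration as drawn), so it bears on this swap only indirectly. Within the data shown here, compound 4 keeps the drawn configuration of compound 3, and no measured step tests this aromatic position. Starting from the low 3 nM of compound 3, a moderate move is expected, a 5.0-fold higher number from compound 3 to compound 4 (0.70 log units; beyond the scatter). For compound 4 the estimated value is 15 nM, within an expected range of 2 nM to 150 nM.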

Compound 4, half-maximal inhibitory concentration: 5 nM
Compound 4: middle estimate off by 3.0-fold (0.48 log units), on the high side; measured number inside the range.
By their numbers in this assay, from the lowest: compound 1; then compounds 3 and 4 (each within the scatter of the next); then compound 2.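

In this assay, cyano in place of fluoro on this aromatic carbon, ortho to a methoxy group, gives a 1.7-fold higher number from compound 3 to compound 4 (0.22 log units; within the scatter), so the two groups cannot be told apart here, although cyano brings a hydrogen-bond acceptor and an extra heavy atom. Within the data shown here, this is the first reading at this position, and it shows that the low number of compound 3 survives this swap. Nothing known about these compounds bears on why. The compounds shown leave open whether an amine, a carboxylic acid or a longer chain on this aromatic carbon would keep the number as low.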